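A few compounds are considered here, and "the series" means these few. Any claim that something is new, unique, unknown or untested is made for them only; others in the source may bear on it.

Compound 3 `CO[C@H]1C[C@H](O)C[C@@H](CSc2nc(-c3ccccc3)c(-c3ccccc3)[nH]2)O1` gives 90 nM in an assay on microsomes from liver for inhibition of sterol O-acyltransferase 1 (Rattus norvegicus); a higher number here means a weaker inhibitor, a lower number a stronger inhibitor. Compound 1 `CC(O)(CC(=O)OC(C)(C)C)CC(O)CSc1nc(-c2ccc(Cl)cc2)c(-c2ccc(Cl)cc2)[nH]1` gives 250 nM in this assay. Compound 2 `CC1=CC(=O)OC(CSc2nc(-c3cccc(Cl)c3)c(-c3cccc(Cl)c3)[nH]2)C1` gives 440 nM in this assay.

Of these three numbers, compound 3 holds the lowest; compound 1 is the nearest and compound 2 the furthest, both gaps lying beyond the scatter. Compound 4 `COC(CSc1nc(-c2ccccc2)c(-c2ccccc2)[nH]1)OC` has not yet been measured in this assay. It differs from compound 3 at one place (a group of 5 heavy atoms (3 carbon, 2 oxygen; no ring) in place of a group of 9 heavy atoms (6 carbon, 3 oxygen; one six-membered non-aromatic ring with 1 hetero atom), on a saturated chain carbon bound to a sulfur). Within the data shown here, no step between measured compounds matches this change, so no direct guide exists. Compound 4 is expected to show a moderate step towards a higher number a 3.3-fold higher number from compound 3 to compound 4 (0.52 log units; beyond the scatter). Compound 4 is estimated at 300 nM, within a range of 80 nM to 1200 nM.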

Compound 4, half-maximal inhibitory concentration: 580 nM
Estimate against measurement, compound 4: 1.9-fold (0.29 log units) below; the range from low to high includes it.
By their numbers in this assay, from the lowest: compound 3; then compounds 1, 2 and 4 (each within the scatter of the next, the first and the last beyond it).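

In this assay, among these compounds, the pair gives the first reading of a single change on a saturated chain carbon bound to a sulfur: dimethoxymethyl in place of the six-membered ring group gives a 6.4-fold higher number from compound 3 to compound 4 (0.81 log units; beyond the scatter), beyond the scatter. Among the compounds shown here, no earlier pair differed in one place only. Nothing measured here accounts for this step. The change removes the ring, the hydrogen-bond donor and the defined stereocentres together, and the compounds shown do not separate them. From the compounds shown here alone, how an amine, a carboxylic acid or a longer chain would fare at this place also remains open.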